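Swapping ethyl for cyclopropyl on an amide-type nitrogen

The source may hold more compounds than are shown below. What is called first, only, known or untested is meant among the compounds shown, and "the series" means these compounds.

- Compound 1 `O=C(Nc1ccccc1)Nc1ccc(-c2nc(N3CC4CCC(C3)O4)c3cnn(C4CCC5(CC4)OCCO5)c3n2)cc1` gives > 0.5 h, which is a limit.
- Compound 2 `O=C(Nc1ccncc1)Nc1ccc(-c2nc(N3CC4CCC(C3)O4)c3cnn(C4CCC5(CC4)OCCO5)c3n2)cc1` gives > 0.5 h, which is a limit.
- Compound 3 `CCNC(=O)Nc1ccc(-c2nc(N3CC4CCC(C3)O4)c3cnn(C4CCC5(CC4)OCCO5)c3n2)cc1` gives 0.45 h.

All three were tested in an in vitro ADME assay on microsomes (Mus musculus) for metabolic stability; on this read-out higher numbers stand for a longer-lived compound and lower numbers for a shorter-lived compound. Going by the values given here, compound 3 carries the only actual number. Compounds 1 and 2 stand at the limit of > 0.5 h in this assay, at which 2 of the 3 values shown sit.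

Compound 4 `O=C(Nc1ccc(-c2nc(N3CC4CCC(C3)O4)c3cnn(C4CCC5(CC4)OCCO5)c3n2)cc1)NC1CC1` comes from compound 3 through a single change: cyclopropyl in place of ethyl on an amide-type nitrogen. In words, cyclopropyl sits in place of ethyl on an amide-type nitrogen.

Among the compounds with values here, three measured steps concern that same nitrogen, though none involves cyclopropyl. The first is an at least 1.1-fold lower number from compound 1 to compound 3 (0.04 log units; that floor lies within the scatter), and the second is an at least 1.1-fold lower number from compound 2 to compound 3 (0.04 log units; that floor lies within the scatter). The third is a step that the two limits leave unreadable from compound 1 to compound 2. None of them shows a change beyond the scatter, so the expectation in this assay is for no clear shift in either direction, starting from compound 3 at 0.45 h.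

The expected step is no change at the digits printed from compound 3 to compound 4 (within the scatter).

Compound 4 is estimated at 0.45 h, with an expected range of 0.25 h to 0.8 h.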

Compound 4, half-life: 0.417 h
For compound 4 the middle estimate is 1.1-fold (0.03 log units) above the measured one, within the range that was stated.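

In this assay, the amide-type nitrogen now has a step between two actual numbers, and it is a step to a ring: a 1.1-fold lower number from compound 3 to compound 4 (0.03 log units; within the scatter). Cyclopropyl and ethyl therefore cannot be told apart at this position, even though cyclopropyl brings one more carbon and a three-membered ring. Against the phenyl and pyridin-4-yl groups only floors can be read, an at least 1.1-fold lower number from compound 2 to compound 4 (0.07 log units; that floor lies within the scatter) and an at least 1.1-fold lower number from compound 1 to compound 4 (0.07 log units; that floor lies within the scatter), so neither step separates compound 4 from those two compounds.

On these data alone, how far the phenyl and pyridin-4-yl compounds truly stand from compound 3 and compound 4 stays open because their values are limits: the limit of > 0.5 h in this assay, at which 2 of the 4 values shown sit. Also open, as far as these compounds go, is whether a longer chain such as butyl, or a chain ending in an amine, would move the half-life beyond the scatter at this nitrogen.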